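This account rests on a few compounds, and the source may have more. Where it says the series, first, only, none or still open, it means among the compounds named here.

Compound 1 `Cc1cc(NC(=O)Cn2nnc(-c3ccccc3)n2)n(C2CCCCC2)n1`: 2920 mL/min/kg
Compound 2 `Cc1cc(NC(=S)Cn2nnc(-c3ccccc3)n2)n(C2CCCCC2)n1`: > 5930 mL/min/kg

Both values come from an ADME assay on microsomes from liver (Mus musculus) for metabolic stability; a higher number here means faster removal of the compound, a lower number slower removal. In this assay, among the compounds with values here, compound 1 gives 2920 mL/min/kg, the only plain number in the set. For compound 2 this assay reports only a limit, > 5930 mL/min/kg. Within the data shown here, compound 1 therefore stands alone with its number, the other value being (the limit of > 5930 mL/min/kg in this assay, at which 1 of the 2 values shown sits), and no step between two measured numbers is available for comparison.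

Compound 3 `Cc1cc(NC(=O)Cn2nnc(-c3ccccc3)n2)n(C2CCC(F)(F)CC2)n1` has not yet been measured. It differs from compound 1 in one place: 4,4-difluorocyclohexyl in place of cyclohexyl on an aromatic nitrogen. Without any measured step of this kind to draw on, the expectation for compound 3 rests on that change alone; a modest move toward slower removal is expected, a 1.9-fold lower number from compound 1 to compound 3 (0.29 log units; within the scatter), though a result within the usual scatter would be no surprise. Compound 3 is thus estimated at 1500 mL/min/kg in this assay, with a range from 600 mL/min/kg to 4000 mL/min/kg.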

Compound 3, clearance: 723 mL/min/kg
The estimate for compound 3 lay 2.1-fold (0.32 log units) above the measured number; the measured number falls inside the stated range.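

In this assay, putting 4,4-difluorocyclohexyl in place of cyclohexyl on an aromatic nitrogen gives a 4.0-fold lower number from compound 1 to compound 3 (0.61 log units; beyond the scatter), a step that lies beyond the usual scatter. Within the data shown here, this is the first step in the set between two plain numbers, and it shows that the group on this nitrogen affects how fast the compound is removed, even when the six-membered ring stays and only fluorine enters it. Nothing measured here accounts for the drop.

On these data alone, whether other groups on this nitrogen, such as a cyclopentyl, a tetrahydropyranyl or a 4-fluorocyclohexyl ring, would give a lower number remains open. Also open, as far as these compounds go, is whether the same change would lower the number for compound 2, whose reading is only a limit.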